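From Compound 1 to Compound 4: an Aryl Exchange

A few compounds are considered here, and "the series" means these few. Any claim that something is new, unique, unknown or untested is made for them only; others in the source may bear on it.

Measured compounds:
compound 1 `COc1ccccc1-c1csc(N/N=C/c2cc(OC)c(OC)c(Br)c2Br)n1` — > 100000 nM
compound 2 `Fc1ccc(/C=N/Nc2nc(-c3ccc(C(F)(F)F)cc3)cs2)cc1F` — 79500 nM
compound 3 `COc1ccccc1-c1csc(N/N=C/c2cc(Br)c(OC)c(OC)c2)n1` — > 100000 nM

The data come from an ADME assay on HUVEC cells (Homo sapiens) for inhibition, read by MTT assay, with a stated time of 48 h; on this read-out lower numbers stand for stronger inhibition and higher numbers for weaker inhibition. In this assay compound 1 gives > 100000 nM, which is a limit of the assay and not a number. Compound 3 likewise gives > 100000 nM, again a limit. The step that the two limits leave unreadable from compound 1 to compound 3 therefore cannot be read, since both ends sit at the limit of > 100000 nM in this assay, at which 2 of the 3 values shown sit. Among the measured compounds shown here, compound 2 is the only one with a number, giving 79500 nM in this assay, a weak value.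

The unmeasured compound 4 `COc1cc(/C=N/Nc2nc(-c3ccc(F)c(F)c3)cs2)c(Br)c(Br)c1OC` is reached from compound 1 by 3,4-difluorophenyl in place of 2-methoxyphenyl on an aromatic carbon. None of the measured steps bears on this change: the one step shown, from compound 1 to compound 3, concerns a bromo and is unreadable, and compound 2 carries its 3,4-difluorophenyl at a different place while still giving only a weak value. The author therefore expects no step beyond the scatter, and the estimated step of a number no higher from compound 1 to compound 4 (the limit leaves the size open) is taken as flat against a limit. For compound 4 the estimate in this assay is 100000 nM, within 50000 nM to 200000 nM.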

Compound 4, half-maximal inhibitory concentration: 54700 nM
Estimate against measurement, compound 4: 1.8-fold (0.26 log units) above; the measured number falls inside the stated range.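

In this assay, among the compounds shown here, the exchange on the aromatic carbon next to the ring nitrogen gives the first step at this position that has any readable size, an at least 1.8-fold lower number from compound 1 to compound 4 (0.26 log units; that floor lies within the scatter). With 3,4-difluorophenyl in place of 2-methoxyphenyl, compound 4 gives a real number, 54700 nM, so this position tolerates the exchange of one aryl group for another and the core of compound 1 can yield a measurable, if still weak, value. The value of compound 1 is a limit of the assay and not a number, so only a floor can be set on this step, and the floor does not show a change beyond the usual scatter: the limit of > 100000 nM in this assay, at which 2 of the 4 values shown sit.

On these data alone, the true size of the step stays open, as does the question of whether it follows from the two fluoro groups entering or from the methoxy group leaving, which a plain phenyl or a phenyl with a single fluoro at this position would help to separate. Also open, as far as these compounds go, is what an amine or a carboxylic acid on this aryl ring would do to the number, and the step between the two compounds at the limit cannot be read.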